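From 4-methylphenyl to 2-bromophenyl on a shared core

The compounds below may be only part of what the source reports. "The series", "measured", "known", "first", "only" and "open" are said of these compounds alone.

Compound 1 `COc1ccccc1NC(=S)N/N=C/c1ccc2ccccc2n1` gives > 100000 nM as a limit of the assay
Compound 2 `Cc1ccc(NC(=S)N/N=C/c2ccc3ccccc3n2)cc1` gives 86000 nM as a measured number

For the measured compounds named here, in a functional assay on HeLa cells (Homo sapiens) for antiproliferative activity, read by sulforhodamine B assay, with a stated time of 72 h (a lower number here means a stronger inhibitor, a higher number a weaker inhibitor), compound 2 holds 86000 nM as the only true number so far. The value of compound 1 is a limit and not a number. Compound 3 `S=C(N/N=C/c1ccc2ccccc2n1)Nc1ccccc1Br` carries 2-bromophenyl in place of 4-methylphenyl on an amide-type nitrogen. Going by the values given here, only one measured step bears on this place, where 4-methylphenyl came in place of 2-methoxyphenyl. It is an at least 1.1-fold lower number from compound 1 to compound 2 (0.06 log units; that floor lies within the scatter) and so gives a floor rather than a size. No change beyond the scatter is therefore expected in this assay for this new group, and the estimated move is a 1.2-fold lower number from compound 2 to compound 3 (0.09 log units; within the scatter) in either reading. For compound 3 the estimate is 70000 nM with an expected range from 20000 nM to 100000 nM in this assay as a weak result.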

Compound 3, half-maximal inhibitory concentration: > 100000 nM
Compound 3 was reported as a limit; the forecaster's own chance of this, stated with the estimate: 30%; at least 1.4-fold (0.15 log units) between middle value and limit.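

In this assay, for the compounds shown here, 2-bromophenyl in place of 4-methylphenyl on the amide-type nitrogen gives an at least 1.1-fold higher number from compound 2 to compound 3 (0.06 log units; that floor lies within the scatter), so this change shows no real loss or gain, only that the bromine-bearing group brings no measurable improvement. Going by these compounds alone, compound 3 gives > 100000 nM, which is a limit and not a number, and 4-methylphenyl remains the only group here with a measured value. The step between the two compounds that both end in a limit cannot be read, and what this position can show is capped by the range of the assay: the limit of > 100000 nM in this assay, at which 2 of the 3 values shown sit.

Going by these compounds, how far compound 3 lies past its limit remains open, and with it the true size of the step. Also open, on these data alone, is whether an amine or a carboxylic acid on the phenyl ring would give a value clearly lower than that of compound 2.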